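The source may report more compounds than this note shows. Statements on the series, on what has been measured and on what is new or still open speak of the compounds shown alone.

In a functional assay on NCI-H460 cells (Homo sapiens) for cytotoxicity, read by MTT assay, with a stated time of 72 h (a lower number here means a stronger inhibitor of growth, a higher number a weaker inhibitor of growth), compound 1, `Cc1ccc(/C=C(/C#N)C(=O)c2ccc[nH]2)cc1`, gives 11000 nM. Compound 2, `N#C/C(=C/c1ccc([N+](=O)[O-])cc1)C(=O)c1ccc[nH]1`, is reported only as a limit, < 10000 nM. Compound 3, `N#C/C(=C/c1ccc(O)cc1)C(=O)c1ccc[nH]1`, also stands only at a limit, < 10000 nM. Compound 4, `COc1ccc(/C=C(/C#N)C(=O)c2ccc[nH]2)cc1`, changes compound 3 from hydroxy to methoxy, with methyl in place of hydrogen on an oxygen on an aromatic ring. Among the compounds with values here, no measured step covers this exact change. The closest ones replace the methyl on an aromatic carbon: an at least 1.1-fold lower number from compound 1 to compound 2 (0.04 log units; that floor lies within the scatter), and an at least 1.1-fold lower number from compound 1 to compound 3 (0.04 log units; that floor lies within the scatter). Neither shows a change beyond the scatter, so no step beyond the scatter is expected in this assay. The expected step is a step that the limit leaves unreadable from compound 3 to compound 4. The estimated value for compound 4 is 7000 nM, with an expected range of 2500 nM to 15000 nM.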

Compound 4, concentration for 50% growth inhibition: 24000 nM
Beside the measured number, compound 4's estimate is 3.4-fold (0.54 log units) below it; the measured number lies above the stated range.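

Unlike the earlier steps, replacing the hydrogen of the hydroxy in compound 3 with methyl gives a change beyond the scatter in this assay (an at least 2.4-fold higher number from compound 3 to compound 4 (0.38 log units; beyond the scatter)). Methoxy also gives a higher number when it replaces other groups on the aromatic carbon (an at least 2.4-fold higher number from compound 2 to compound 4 (0.38 log units; beyond the scatter); a 2.2-fold higher number from compound 1 to compound 4 (0.34 log units; beyond the scatter)). The first two steps are minimum sizes, since compound 2 and compound 3 are each reported only as a limit: the limit of < 10000 nM in this assay, at which 2 of the 4 values shown sit.

On these data alone, whether a longer chain on this oxygen, such as ethoxy, would raise the number further remains open. So does the effect of an amine on the aromatic carbon.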